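The source may hold more compounds than are shown below. What is called first, only, known or untested is meant among the compounds shown, and "the series" means these compounds.

Three compounds have been measured in a functional assay on HeLa cells (Homo sapiens) for antiproliferative activity, with a stated time of 24 h; a higher number here means a weaker inhibitor, a lower number a stronger inhibitor:

compound 1 `N#Cc1ccccc1CN1CCc2c(sc(NC(=O)c3ccccc3Cl)c2C(N)=O)C1`: > 50000 nM, a limit of the assay
compound 2 `NC(=O)c1c(NC(=O)c2ccccc2Cl)sc2c1CCN(C(=O)Nc1ccccc1Cl)C2`: 45400 nM
compound 3 `NC(=O)c1c(NC(=O)c2ccccc2Cl)sc2c1CCN(C(=S)Nc1c(Cl)cccc1Cl)C2`: 26500 nM

Compound 2 stands highest of the two numbers; compound 3 lies a 1.7-fold lower number from compound 2 to compound 3 (0.23 log units; within the scatter), within the scatter, so the two are not ordered. The value of compound 1 is only a limit, at the limit of > 50000 nM in this assay, at which 1 of the 3 values shown sits. Compound 4 `Cc1ccc(C(=O)Nc2sc3c(c2C(N)=O)CCN(C(=O)Nc2ccccc2Cl)C3)cc1` differs from compound 2 by 4-methylphenyl in place of 2-chlorophenyl on a carbonyl carbon. Within the data shown here, the measured steps, an at least 1.1-fold lower number from compound 1 to compound 2 (0.04 log units; that floor lies within the scatter) and an at least 1.8-fold lower number from compound 1 to compound 3 (0.27 log units; that floor lies within the scatter), both concern the amine nitrogen in the ring, not the carbonyl carbon; no measured step bears on the change to compound 4. No step beyond the scatter is therefore expected. Compound 4 is estimated at 45000 nM, between 18000 nM and 110000 nM, an expected step of a 1.0-fold lower number from compound 2 to compound 4 (0.00 log units; within the scatter).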

Compound 4, half-maximal inhibitory concentration: 32900 nM
Beside the measured number, compound 4's estimate is 1.4-fold (0.14 log units) above it, and the stated range covers the measured number.
By their numbers in this assay, from the lowest: compounds 3, 4 and 2 (each within the scatter of the next). At a limit, above all of these: compound 1.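

Among these compounds, the exchange of 2-chlorophenyl for 4-methylphenyl gives a 1.4-fold lower number from compound 2 to compound 4 (0.14 log units; within the scatter) in this assay, the first measured step on the carbonyl carbon rather than on the amine nitrogen in the ring. This one exchange therefore moves the number by no more than the scatter, even though the chlorine gives way to a methyl group and the ring carries its substituent at a different place. Nothing measured here bears on a cause for this step. From the compounds shown here alone, whether an amine, a carboxylic acid or a longer chain on that carbonyl carbon would give a step beyond the scatter remains open. So does whether changes at the two places combine independently.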